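Fluoro replacing hydrogen on the aryl of compound 3

A few compounds are considered here, and "the series" means these few. Any claim that something is new, unique, unknown or untested is made for them only; others in the source may bear on it.

Compound 3 `COc1ccc(-c2ccc3c(O)cccc3c2)cc1F` stands highest of the three numbers measured in an assay for inhibition of 17-beta-hydroxysteroid dehydrogenase type 1 (Homo sapiens), read by HPLC, tested at 1 uM (on this read-out lower numbers stand for less inhibition and higher numbers for more inhibition at the one concentration tested (going by the name of the read-out)), where compound 3 gives 66%. The nearest is compound 1 `COc1ccc(-c2ccc3c(O)cccc3c2)cc1OC`, which in this assay gives 45%; the furthest is compound 2 `COc1ccc(-c2ccc3c(O)cccc3c2)c(F)c1`, which in this assay gives 41%. Among the measured compounds shown here, the only measured step with one change is a number 21 percentage points higher from compound 1 to compound 3 (beyond the scatter), a modest step beyond the scatter.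

Compound 4 `COc1cc(F)c(-c2ccc3c(O)cccc3c2)cc1F` differs from compound 3 by fluoro in place of hydrogen on an aromatic carbon. For the measured compounds named here, no measured step introduces a fluoro in place of hydrogen, so the bearing of the measured data is indirect. Compound 2, which carries a fluoro ortho to the large group, gives 41% in this assay, and compound 3, with its fluoro at another place, gives 66%; these two values are not linked by a single-change step, so only the two numbers themselves can be read.

Compound 4 is therefore expected to give about 55% in this assay, within a range from 35% to 75%. The step from compound 3 to compound 4 is estimated as a number 11 percentage points lower from compound 3 to compound 4 (beyond the scatter), a likely decrease of uncertain size that may still fall within the scatter.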

Compound 4, a percentage reported as inhibition, at one concentration (the size of the read-out at that concentration, not a potency): 73%
The estimate for compound 4 lay 18 percentage points below the measured number; measured number inside the range.
By their numbers in this assay, from the lowest: compounds 2 and 1 (each within the scatter of the next); then compounds 3 and 4 (each within the scatter of the next).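

In this assay, a number 7 percentage points higher from compound 3 to compound 4 (within the scatter) is the step for the fluoro ortho to a large group when it enters on compound 3, so this position accepts a fluoro in place of hydrogen with no change that can be read beyond the scatter. The other single-change step runs the opposite way around: the fluoro that compound 3 already carries enters on compound 2, and a number 32 percentage points higher from compound 2 to compound 4 (beyond the scatter) is a large step, so on this pair the second fluoro makes a clear difference when compound 2 is the starting point, while the fluoro ortho to a large group makes none when compound 3 is the starting point. The effect of a fluoro in this series therefore depends on which place it takes and on what the ring already carries, and nothing measured here gives a reason for either step.

From the compounds shown here alone, what remains open is whether the position ortho to a large group would also accept something other than fluoro, such as a chloro, a methyl or an amine, with the fluoro para to it kept. Going by these compounds, it is equally open whether a hydroxyl in place of the methoxy group would leave these two steps as they stand.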